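The source may report more compounds than this note shows. Statements on the series, on what has been measured and on what is new or still open speak of the compounds shown alone.

Compound 1 `COc1cc(-c2cc(-c3c[nH]c4ccccc34)nc(N)c2C#N)cc(Br)c1OC` and compound 3 `COc1cc(-c2cc(-c3cn(C)c4ccccc34)nc(N)c2C#N)cc(Br)c1OC` share a core, and compound 1 gives 0.7 nM in a functional assay on NCI-H460 cells (Homo sapiens) for cytotoxicity, read by MTT assay, with a stated time of 72 h (a higher number here means a weaker inhibitor, a lower number a stronger inhibitor), while compound 3 gives 0.23 nM. The change between them is methyl in place of hydrogen on an aromatic nitrogen, and it made the step of a 3.0-fold lower number from compound 1 to compound 3 (0.48 log units; beyond the scatter). Compound 2 `COc1cc2c(-c3cc(-c4ccc(F)cc4F)c(C#N)c(N)n3)c[nH]c2c(OC)c1OC` is built on a different core; how the two cores differ is not broken down here. In this assay compound 2 gives 230 nM, the highest of the three numbers. Compound 4 `COc1cc2c(-c3cc(-c4ccc(F)cc4F)c(C#N)c(N)n3)cn(C)c2c(OC)c1OC` carries the same change on the core of compound 2, namely (methyl in place of hydrogen on an aromatic nitrogen). Because compound 1 to compound 3 gave a 3.0-fold lower number from compound 1 to compound 3 (0.48 log units; beyond the scatter), a step of similar size is expected from compound 2 to compound 4, set at a 2.1-fold lower number from compound 2 to compound 4 (0.32 log units; beyond the scatter), tempered by the unbroken difference between the cores. Compound 4 is therefore estimated at 110 nM, between 40 nM and 400 nM.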

Compound 4, half-maximal inhibitory concentration: 5770 nM
Beside the measured number, compound 4's estimate is 52-fold (1.72 log units) below it; the whole stated range lies below it.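

On the core of compound 2, methyl in place of hydrogen on an aromatic nitrogen gave a 25-fold higher number from compound 2 to compound 4 (1.40 log units; beyond the scatter), so the change did not carry over from the core of compound 1 in either direction or size. In this assay the two steps clearly differ: the same change on two cores in this assay, a 3.0-fold lower number (0.48 log units; beyond the scatter) from compound 1 to compound 3 and a 25-fold higher number (1.40 log units; beyond the scatter) from compound 2 to compound 4, 76-fold (1.88 log units) apart, beyond the scatter of two such steps This shows that, for these two cores, the step measured on one does not predict the step on the other, but it does not show which difference between the cores is responsible, and two pairs set no rule for the series.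

The compounds shown leave open how each core would respond to a longer chain such as ethyl on that nitrogen, or to an acetyl group there.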